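The compounds below may be only part of what the source reports. "The series", "measured", "known", "first", "only" and "open" are said of these compounds alone.

Two compounds of this series carry numbers in an assay on isolated protein for inhibition of Amine oxidase [flavin-containing] B (Homo sapiens); on this read-out higher numbers stand for weaker inhibition and lower numbers for stronger inhibition. Compound 1 `C#CCNC1CCc2c(SCCc3ccc(Cl)cc3)cccc21` gives 10800 nM. Among the measured compounds shown here, compound 2 `C#CCNC1CCc2c(SCCc3cccc(F)c3)cccc21` gives 4300 nM, the lowest of the two numbers; the single step on record, a 2.5-fold lower number from compound 1 to compound 2 (0.40 log units; beyond the scatter), is modest. Compound 3 `C#CCNC1CCc2c(SCCc3ccc(F)c(F)c3)cccc21` carries fluoro in place of hydrogen on an aromatic carbon. For the measured compounds named here, no measured step adds a fluoro to an aromatic carbon, so the bearing is indirect: the compound bearing 4-chlorophenyl, compound 1, gave the higher number, and compound 3 again places a group at that ring carbon. A small rise, possibly within the scatter, is therefore expected: a 1.4-fold higher number from compound 2 to compound 3 (0.14 log units; within the scatter). Compound 3 is estimated at 6000 nM, range 2500 nM to 14000 nM.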

Compound 3, half-maximal inhibitory concentration: 3240 nM
Compound 3: the middle estimate sits 1.9-fold (0.27 log units) above what was measured, and the stated range covers the measured number.
By their numbers in this assay, from the lowest: compounds 3 and 2 (each within the scatter of the next); then compound 1.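

Fluoro on this aromatic carbon, ortho to a fluoro group and para to a large group, leaves 3,4-difluorophenyl indistinguishable from 3-fluorophenyl (a 1.3-fold lower number from compound 2 to compound 3 (0.12 log units; within the scatter)). The 3,4-difluorophenyl compound still stands apart from the 4-chlorophenyl one (a 3.3-fold lower number from compound 1 to compound 3 (0.52 log units; beyond the scatter)), so a group at this ring carbon does not by itself go with the higher number seen for compound 1. Nothing on record explains either step.

Still open, from the compounds shown here alone, is how a larger group at this ring carbon, such as methoxy or trifluoromethyl, would read. Also open, going by these compounds, is whether 3-chlorophenyl would match 3-fluorophenyl.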